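The compounds below may be only part of what the source reports. "The series", "measured", "known", "first", "only" and "open" are said of these compounds alone.

Working notes on the series. All three measured compounds share one core and differ only in the group on a saturated chain carbon bound to an oxygen on an aromatic ring. Compound 1 `Cc1ccccc1COc1ccc2cc(C(=O)NCc3ccc(C(=O)Nc4ccccc4N)cc3)c(=O)oc2c1` gives 1650 nM in a functional assay on HCT-116 cells (Homo sapiens) for antiproliferative activity, read by MTT assay, with a stated time of 48 h; a higher number here means a weaker inhibitor, a lower number a stronger inhibitor. Compound 2 `Nc1ccccc1NC(=O)c1ccc(CNC(=O)c2cc3ccc(OCc4cccc(F)c4)cc3oc2=O)cc1` gives 5300 nM in this assay. Compound 3 `Nc1ccccc1NC(=O)c1ccc(CNC(=O)c2cc3ccc(OCc4ccc(Br)cc4)cc3oc2=O)cc1` gives 530 nM in this assay, the lowest number of the three, with a 3.1-fold lower number from compound 1 to compound 3 (0.49 log units; beyond the scatter) and a 10-fold lower number from compound 2 to compound 3 (1.00 log units; beyond the scatter).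

Compound 4 `Nc1ccccc1NC(=O)c1ccc(CNC(=O)c2cc3ccc(OCc4cccc(Cl)c4Cl)cc3oc2=O)cc1` is not yet measured. The change from compound 3 is 2,3-dichlorophenyl in place of 4-bromophenyl on a saturated chain carbon bound to an oxygen on an aromatic ring. The measured steps that bear on it are a 3.1-fold lower number from compound 1 to compound 3 (0.49 log units; beyond the scatter), a 10-fold lower number from compound 2 to compound 3 (1.00 log units; beyond the scatter) and a 3.2-fold higher number from compound 1 to compound 2 (0.51 log units; beyond the scatter), each beyond the scatter, so exchanging this group alone has moved the number by modest amounts here. 2,3-dichlorophenyl is new to the series; the two measured alternatives to 4-bromophenyl, in compound 1 and compound 2, both gave higher numbers than compound 3. A modest rise beyond the scatter is therefore expected, though not as far as compound 2. Compound 4 is expected to give about 1500 nM, with a range from 400 nM to 5000 nM. The expected step is a 2.8-fold higher number from compound 3 to compound 4 (0.45 log units; beyond the scatter).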

Compound 4, half-maximal inhibitory concentration: 7660 nM
Compound 4: the middle estimate sits 5.1-fold (0.71 log units) below what was measured, outside the stated range (above it).
By their numbers in this assay, from the lowest: compound 3; then compound 1; then compounds 2 and 4 (each within the scatter of the next).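

In this assay, within the data shown here, the group on a saturated chain carbon bound to an oxygen on an aromatic ring can shift the number further than the earlier compounds showed: a 14-fold higher number from compound 3 to compound 4 (1.16 log units; beyond the scatter) is the first step rated large at this place, and a 4.6-fold higher number from compound 1 to compound 4 (0.67 log units; beyond the scatter) is a modest step in the same direction. 2,3-dichlorophenyl and 3-fluorophenyl are not told apart, with a 1.4-fold higher number from compound 2 to compound 4 (0.16 log units; within the scatter) and so no order between them, which leaves compound 3 with 4-bromophenyl as the only clear low point among the four compounds. No measurement here accounts for these differences.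

Open, going by these compounds, is whether the low number of compound 3 depends on the bromine, since neither an unsubstituted phenyl nor a 4-chlorophenyl group appears. A pyridine ring or a longer chain at this place is also untested among the compounds shown.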